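The compounds below may be only part of what the source reports. "The series", "measured", "known", "first", "only" and "open" are said of these compounds alone.

Compounds measured so far in a functional assay on RAW264.7 cells (Mus musculus) for inhibition, read by fluorescence, with stated times of 1 h, 24 h and 30 min; a lower number here means a stronger inhibitor, a higher number a weaker inhibitor:
compound 1, `O=C(/C=C/c1ccccc1C(F)(F)F)c1cccc(O)c1`, > 10000 nM;
compound 2, `O=C(/C=C/c1ccccc1C(F)(F)F)c1ccc(O)cc1`, > 10000 nM;
compound 3, `O=C(/C=C/c1cccc(C(F)(F)F)c1)c1cccc(O)c1`, "not determined" (no result reported).

For compound 1 the value in this assay is a limit of the assay, not a number. For compound 2 the value is likewise a limit. The two sit at the same limit, (the limit of > 10000 nM in this assay, at which 2 of the 3 values shown sit), so the step that the two limits leave unreadable from compound 1 to compound 2 cannot be read. The change behind that step is 4-hydroxyphenyl in place of 3-hydroxyphenyl on a carbonyl carbon. Compound 3 carries a different core; how the two cores differ is not broken down here. Compound 4, `O=C(/C=C/c1cccc(C(F)(F)F)c1)c1ccc(O)cc1`, is not yet measured and differs from compound 3 by the same change, (4-hydroxyphenyl in place of 3-hydroxyphenyl on a carbonyl carbon). Since the step from compound 1 to compound 2 is unreadable, no size can be set beside it. Compound 4 is expected to come out near 15000 nM, and more likely as a limit than as a number.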

Compound 4, half-maximal inhibitory concentration: 1440 nM
For compound 4 the middle estimate is 10-fold (1.02 log units) above the measured one, and the stated range ends above it.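

Within the data shown here, compound 3 gives no number in this assay, so no step from it to compound 4 can be read, and the 1440 nM of compound 4 stands alone. The compounds shown leave open whether 4-hydroxyphenyl in place of 3-hydroxyphenyl changes inhibition on either core, because compound 1 and compound 2 share one limit: the limit of > 10000 nM in this assay, at which 2 of the 4 values shown sit.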